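The source may report more compounds than this note shows. Statements on the series, on what has been measured and on what is new or still open speak of the compounds shown alone.

Measured compounds:
Compound 1 `CC(=O)Nc1ccc2oc(-c3cccc(F)c3)c(O)c(=O)c2c1`: 36000 nM
Compound 2 `Nc1ccc2oc(-c3cccc(F)c3)c(O)c(=O)c2c1`: 30000 nM
Compound 3 `COc1c(-c2ccccc2)oc2ccc(NC(C)=O)cc2c1=O`: > 125000 nM

In an ADME assay on THP-1 cells (Homo sapiens) for cytotoxicity, read by flow cytometry and propidium iodide staining, with a stated time of 72 h (on this read-out lower numbers stand for stronger inhibition and higher numbers for weaker inhibition), compound 1 gives 36000 nM and compound 2 gives 30000 nM. The two differ by hydrogen in place of acetyl on a nitrogen on an aromatic ring, and this step gives a 1.2-fold lower number from compound 1 to compound 2 (0.08 log units; within the scatter), so the two values sit within the scatter of each other. Compound 3 belongs to a different core, and the difference between the two cores is not broken down here. For compound 3 this assay reports only a limit, > 125000 nM, rather than a number (the limit of > 125000 nM in this assay, at which 1 of the 3 values shown sits).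

Compound 4 `COc1c(-c2ccccc2)oc2ccc(N)cc2c1=O` has not yet been measured. It differs from compound 3 by hydrogen in place of acetyl on a nitrogen on an aromatic ring, the same change that was made from compound 1 to compound 2. Since compound 2 gave 30000 nM after that change, with no step beyond the scatter, compound 4 is expected to stay close to compound 3, that is, a step that the limit leaves unreadable from compound 3 to compound 4 is estimated. Compound 4 is therefore expected to land around 150000 nM, between 60000 nM and 400000 nM, and most likely this assay will again report only a limit.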

Compound 4, half-maximal inhibitory concentration: 74000 nM
Compound 4: middle estimate off by 2.0-fold (0.31 log units), on the high side; low and high end bracket the measured number.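

Replacing the acetyl on the nitrogen with hydrogen, which turns acetamido into amino, gives in this assay an at least 1.6-fold lower number from compound 3 to compound 4 (0.22 log units; that floor lies within the scatter). Set beside the same change on the other core, this result cannot show whether the change carries over with the same size: the same change on two cores in this assay, a 1.2-fold lower number (0.08 log units; within the scatter) from compound 1 to compound 2 and an at least 1.6-fold lower number (0.22 log units; that floor lies within the scatter) from compound 3 to compound 4; the limit leaves it open whether they differ

The step on the core of compound 1 stays within the scatter, while the true size of the step on the core of compound 3 remains unknown, because the starting point there is only a limit and not a number: the limit of > 125000 nM in this assay, at which 1 of the 4 values shown sits.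

The compounds shown leave open what happens when the acetyl is replaced by a different group on the nitrogen, such as a methyl group or a longer acyl chain. On these data alone, they also do not separate the parts of the difference between the two cores, so it remains open whether any one of those parts would alter the size of this step.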